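From Propyl to Cyclopentyl on the Ring Amine

This account rests on a few compounds, and the source may have more. Where it says the series, first, only, none or still open, it means among the compounds named here.

Three compounds have been measured in an in vitro functional assay on cells for antagonist activity at B1 bradykinin receptor (Homo sapiens), read by luminescence and calcium flux, with a stated time of 2 h; on this read-out higher numbers stand for weaker inhibition and lower numbers for stronger inhibition:
compound 1 `Cc1ccc(S(=O)(=O)N2C=CNC(=O)[C@H]2CC(=O)N[C@@H]2CCCc3ccccc32)cc1` gives 3.3 nM;
compound 2 `CC(=O)N1CCC(NC(=O)C[C@@H]2C(=O)NC=CN2S(=O)(=O)c2ccc(C)cc2)c2ccccc21` gives 72.2 nM;
compound 3 `CCCN1CC[C@H](NC(=O)C[C@@H]2C(=O)NC=CN2S(=O)(=O)c2ccc(C)cc2)C(C)(C)C1` gives 0.51 nM.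

Among these three, compound 3 stands lowest in this assay, and so is the strongest inhibitor of the set. Compound 1 comes nearest to it, yet the gap between compound 3 and compound 1 is beyond the usual scatter; compound 2 lies furthest away, again well beyond the scatter. All three share the same core, and the three differ in the amine-bearing part attached to the amide.

Compound 4 `Cc1ccc(S(=O)(=O)N2C=CNC(=O)[C@H]2CC(=O)N[C@H]2CCN(C3CCCC3)CC2(C)C)cc1` is not yet measured. It differs from compound 3 in one place: cyclopentyl in place of propyl on an amine nitrogen in a ring. In words, the change is cyclopentyl in place of propyl on an amine nitrogen in a ring, with the rest of the molecule unchanged.

Going by the values given here, no pair of measured compounds shows this kind of exchange, so there is no measured step to lean on. Because compound 3 already gives 0.51 nM, the estimate starts from there. The estimated step of a 1.2-fold higher number from compound 3 to compound 4 (0.07 log units; within the scatter) is expected to stay within the scatter, with no clear direction. Compound 4 is therefore expected to give 0.6 nM, with a range from 0.2 nM to 2 nM.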

Compound 4, half-maximal inhibitory concentration: 0.247 nM
Beside the measured number, compound 4's estimate is 2.4-fold (0.39 log units) above it; the measured number falls inside the stated range.
By their numbers in this assay, from the lowest: compound 4; then compound 3; then compound 1; then compound 2.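

Going by these compounds alone, on the amine nitrogen in the ring, two ring bonds from the ring atom that bears two methyl groups, the earlier compounds offered only propyl, so they gave no sign of how this position responds to a change of group. In this assay the exchange of propyl for cyclopentyl, which brings five heavy atoms in place of three and one five-membered ring of carbon only, gives a 2.1-fold lower number from compound 3 to compound 4 (0.31 log units; beyond the scatter) and so shows that this position accepts a ring and that the number moves modestly down, a small but real shift from an already low value. Nothing shown here bears on why the number moves in this way.

This single step cannot say whether the same direction would hold for a cyclobutyl or cyclohexyl ring, for a branched chain such as isopropyl, or for a ring carrying oxygen such as tetrahydropyranyl. It also leaves open whether cyclopentyl would have the same effect on a ring without the two methyl groups, or with a hydrogen alone on the amine nitrogen.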